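A Fluorine Added to a Weak Inhibitor

A few compounds are considered here, and "the series" means these few. Any claim that something is new, unique, unknown or untested is made for them only; others in the source may bear on it.

Compound 1 `COC(=O)C(c1ccccc1Cl)N1CCC(O)(Cn2cnc3c(cnn3-c3ccc(F)cc3)c2=O)CC1` was entered into an assay on Sf21 cells for inhibition of ubiquitin carboxyl-terminal hydrolase 7 (Homo sapiens), read by spectrophotometry, with stated times of 30 min and 2 h (on this read-out higher numbers stand for weaker inhibition and lower numbers for stronger inhibition), but for compound 1 the entry reads "not determined" (no result reported), with no result reported. For the measured compounds named here, compound 2 `COC(=O)c1ccc(CN2CCC(O)(Cn3cnc4c(cnn4-c4ccc(F)cc4)c3=O)CC2)cc1` is therefore the only compound with a number: in this assay compound 2 gives 4500 nM. Compound 3 `COC(=O)c1ccc(CN2CCC(O)(Cn3cnc4c(cnn4-c4ccc(F)cc4)c3=O)CC2)c(F)c1` differs from compound 2 in one place: fluoro in place of hydrogen on an aromatic carbon. Going by the values given here, no measured pair shows what this change does here, so the step from compound 2 to compound 3 is expected to stay within the usual scatter, in either direction. The expected step is a 1.1-fold lower number from compound 2 to compound 3 (0.05 log units; within the scatter). Compound 3 is accordingly estimated at 4000 nM in this assay, with a range from 1500 nM to 12000 nM.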

Compound 3, half-maximal inhibitory concentration: 800 nM
Compound 3: middle estimate off by 5.0-fold (0.70 log units), on the high side; measured number outside the range, below it.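

In this assay, replacing 4-(methoxycarbonyl)benzyl with 2-fluoro-4-(methoxycarbonyl)benzyl gives a 5.6-fold lower number from compound 2 to compound 3 (0.75 log units; beyond the scatter). This shows that the aromatic carbon ortho to a large group is sensitive: one added fluorine atom moves the number towards stronger inhibition, by more than the usual scatter. Nothing available explains why this single atom has such an effect. Open, on these data alone, is whether chloro or methoxy on this same carbon would act like fluoro, or whether fluoro on another carbon of the ring would. Also open, as far as these compounds go, is how a carboxylic acid or an amide would compare with the methoxycarbonyl group.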